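Phenyl for Cyclohexyl: Estimating Compound 3

The compounds below may be only part of what the source reports. "The series", "measured", "known", "first", "only" and "open" are said of these compounds alone.

For the measured compounds named here, compound 1 `COc1ccc(Nc2cc(C3CCCCC3)oc(=O)c2)cc1` gives the higher of the two numbers measured so far in a functional assay on SK-BR-3 cells (Homo sapiens) for cytotoxicity, read by MTT assay, with a stated time of 72 h (on this read-out higher numbers stand for an effect only at larger amounts of compound and lower numbers for an effect already at smaller amounts), at 5.29 uM. Its nearest neighbour, compound 2 `COc1ccccc1Nc1cc(-c2ccccc2)oc(=O)c1`, gives 0.54 uM in this assay, a gap beyond the usual scatter; the two compounds differ in more than one place, so the gap cannot be tied to a single change. Compound 3 `COc1ccc(Nc2cc(-c3ccccc3)oc(=O)c2)cc1` has not yet been measured. It differs from compound 1 in one place: phenyl in place of cyclohexyl on an aromatic carbon. Going by the values given here, no measured pair shows this exact change on its own. Because compound 2 gives 0.54 uM while also bearing phenyl on the shared core, a step toward lower numbers is expected, though of moderate size, as the second difference between compound 1 and compound 2 may carry part of that gap. The expected step of a 3.3-fold lower number from compound 1 to compound 3 (0.52 log units; beyond the scatter) is a moderate one downward. Compound 3 is estimated at 1.6 uM, with a range from 0.4 uM to 6 uM.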

Compound 3, concentration for half-maximal effect: 0.079 uM
The estimate for compound 3 lay 20-fold (1.31 log units) above the measured number; measured number outside the range, below it.
By their numbers in this assay, from the lowest: compound 3; then compound 2; then compound 1.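

In this assay, phenyl in place of cyclohexyl on an aromatic carbon next to the ring oxygen gives a 67-fold lower number from compound 1 to compound 3 (1.83 log units; beyond the scatter), so this single position alone carries a large step, which the earlier pair, differing in more than one place, could not show. The two groups have the same count of heavy atoms and neither has hydrogen-bond donors or acceptors, so the step comes with a six-membered aromatic ring replacing a non-aromatic one while those counts stay unchanged. Nothing at hand explains why the aromatic ring goes with the lower number.

Only phenyl and cyclohexyl are shown at this position, so it remains open how a pyridyl ring or a small methyl group would read here. On these data alone, it is also open whether a phenyl carrying a fluorine or an amine would keep the number this low.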